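The source may hold more compounds than are shown below. What is called first, only, known or untested is meant among the compounds shown, and "the series" means these compounds.

Compound 1 `Nc1nc(OCc2ccccc2)c2ncn(/C=C3/CC3(CO)CO)c2n1` stands at the edge of what an ADME assay on MOLT-3 cells (Homo sapiens) for cytotoxicity, with a stated time of 7 days (a lower number here means that less compound is tolerated, a higher number that more compound is tolerated), can report. In this assay compound 1 gives > 20000 nM, which is a limit of the assay rather than a number. Compound 2 `Nc1nc(NC2CC2)c2ncn(/C=C3/CC3(CO)CO)c2n1` gives > 20000 nM in this assay, again a limit. For compound 3 `CC(C)CNc1nc(N)nc2c1ncn2/C=C1/CC1(CO)CO` the result in this assay is "not determined" (no result reported). Among the measured compounds shown here, the only measured step, a step that the two limits leave unreadable from compound 1 to compound 2, therefore cannot be read, and the one thing the measured values show is the limit of > 20000 nM in this assay, at which 2 of the 3 values shown sit. The unmeasured compound 4 `CC(C)Sc1nc(N)nc2c1ncn2/C=C1/CC1(CO)CO` differs from compound 1 by isopropylsulfanyl in place of benzyloxy on an aromatic carbon. For the measured compounds named here, no measured step bears on this change with a readable size, so nothing points to a shift in either direction beyond the scatter in this assay, and the likeliest outcome is that compound 4 also sits at the same limit. On that basis compound 4 is expected to give about 30000 nM in this assay, between 15000 nM and 100000 nM. The step that the limit leaves unreadable from compound 1 to compound 4 is accordingly estimated to be essentially none.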

Compound 4, half-maximal cytotoxic concentration: > 20000 nM
Compound 4: a limit, no number (the forecaster's own chance of this, stated with the estimate: 85%); the middle value is on the limit's open side.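

No step among compound 1, compound 2 and compound 4 can be read in this assay, and what the values show remains: the limit of > 20000 nM in this assay, at which 3 of the 4 values shown sit.

The compounds shown leave open whether the benzyloxy, cyclopropylamino and isopropylsulfanyl groups differ at all in this read-out, and at what concentration any of these compounds becomes cytotoxic.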